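The compounds below may be only part of what the source reports. "The series", "measured", "known", "first", "only" and "open" are said of these compounds alone.

Measured compounds: compound 1 `CCC1=C(O)c2c(oc(-c3ccc(C)cc3)cc2=O)C(CC)(CC)C1=O` gives 0.08 uM in a functional assay on KBVIN cells (Homo sapiens) for antiproliferative activity, read by sulforhodamine B assay, with a stated time of 3 days; on this read-out higher numbers stand for an effect only at larger amounts of compound and lower numbers for an effect already at smaller amounts; compound 2 `CCCc1ccc(-c2cc(=O)c3c(o2)C(CC)(CC)C(=O)C(CC)=C3O)cc1` gives 12.2 uM; compound 3 `CCC1=C(O)c2c(oc(-c3cccc(OC)c3)cc2=O)C(CC)(CC)C1=O` gives 1.22 uM.

Compound 3 stands second highest of the three numbers, a 10-fold lower number from compound 2 to compound 3 (1.00 log units; beyond the scatter) and a 15-fold higher number from compound 1 to compound 3 (1.18 log units; beyond the scatter). Compound 4 `CCC1=C(O)c2c(oc(-c3ccc(OC)cc3C)cc2=O)C(CC)(CC)C1=O` differs from it by 4-methoxy-2-methylphenyl in place of 3-methoxyphenyl on an aromatic carbon. Among the compounds with values here, two measured steps bear on this change: a 15-fold higher number from compound 1 to compound 3 (1.18 log units; beyond the scatter) and a 10-fold lower number from compound 2 to compound 3 (1.00 log units; beyond the scatter), both large, showing that the substitution pattern on this ring moves the number strongly. Nothing measured covers a methyl beside the attachment point, so the expectation is uncertain. Compound 4 is expected to show a 3.1-fold lower number from compound 3 to compound 4 (0.48 log units; beyond the scatter), a modest step toward a lower number. The estimate for compound 4 is 0.4 uM, within 0.08 uM to 2 uM.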

Compound 4, concentration for half-maximal effect: 2.62 uM
Compound 4: the middle estimate sits 6.6-fold (0.82 log units) below what was measured; measured number above the stated range.
By their numbers in this assay, from the lowest: compound 1; then compound 3; then compound 4; then compound 2.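

In this assay, 4-methoxy-2-methylphenyl brought no gain over 3-methoxyphenyl at this aromatic carbon (a 2.1-fold higher number from compound 3 to compound 4 (0.33 log units; beyond the scatter)). It did lie below 4-propylphenyl (a 4.7-fold lower number from compound 2 to compound 4 (0.67 log units; beyond the scatter)) but far above 4-methylphenyl (a 33-fold higher number from compound 1 to compound 4 (1.52 log units; beyond the scatter)), so none of the other three groups shown here comes near 4-methylphenyl. No measurement shown gives a reason for these steps.

The compounds shown leave open how 4-methoxyphenyl, without the added methyl, would compare, since the methoxy and methyl changes cannot be separated here. They also leave open how a 4-aminophenyl or 4-chlorophenyl group would stand.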